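The source may hold more compounds than are shown below. What is called first, only, known or untested is meant among the compounds shown, and "the series" means these compounds.

In a physicochemical assay for solubility (a lower number here means a less soluble compound, a higher number a more soluble compound), three compounds have been measured so far.
Compound 1, `O=C(NC1(C(=O)NO)CCC1)c1ccc(C#Cc2ccccc2)cc1`: 5000 nM.
Compound 2, `O=C(NC1(C(=O)NO)CCCCC1)c1ccc(C#Cc2ccccc2)cc1`: < 1000 nM, which is a limit of this assay and not a number.
Compound 3, `COCCNC(=O)C[C@H](NC(=O)c1ccc(C#Cc2ccccc2)cc1)C(=O)NO`: 78000 nM.

Compound 3 gives the highest of the two numbers, and its gap to compound 1 lies well beyond the usual scatter. Compound 4, `C#CCNC(=O)C[C@H](NC(=O)c1ccc(C#Cc2ccccc2)cc1)C(=O)NO`, has not yet been measured. It differs from compound 3 in one place: ethynyl in place of methoxymethyl on a saturated chain carbon bound to an amide-type nitrogen. Within the data shown here, no measured pair shows a change of this kind, so the expectation rests on compound 3 alone. A modest fall in solubility is expected, a step of a 2.6-fold lower number from compound 3 to compound 4 (0.41 log units; beyond the scatter) in this assay, though a step within the scatter cannot be ruled out. For compound 4 the estimate is 30000 nM, with a likely range from 8000 nM to 90000 nM.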

Compound 4, solubility: 8000 nM
Estimate against measurement, compound 4: 3.8-fold (0.57 log units) above, and the stated range covers the measured number.
By their numbers in this assay, from the lowest: compounds 1 and 4 (each within the scatter of the next); then compound 3. At a limit, below all of these: compound 2.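

Replacing (2-methoxyethyl)carbamoyl with propargylcarbamoyl gives, in this assay, a 9.8-fold lower number from compound 3 to compound 4 (0.99 log units; beyond the scatter). Among these compounds, with the rest of the molecule unchanged, this shows that the side chain alone can shift the read-out beyond the scatter, which no earlier pair could show. Nothing measured here explains the size of this step.

Going by these compounds, it remains open whether the step follows from losing the ether oxygen or from gaining the triple bond. A plain propyl chain would help separate the two, while an amine or a carboxylic acid on the chain would test a different kind of group.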